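Notes on the step from compound 3 to compound 4

The source may hold more compounds than are shown below. What is called first, only, known or untested is meant among the compounds shown, and "the series" means these compounds.

Measured in a functional assay on HepG2 cells (Homo sapiens) for inhibition, read by MTT assay, with a stated time of 72 h; on this read-out lower numbers stand for stronger inhibition and higher numbers for weaker inhibition:
- Compound 1 `O=C(Nc1ccccc1)C1CCN(C/C=C/c2ccccc2)CC1`: 90900 nM
- Compound 2 `CCc1ccc(NC(=O)C2CCN(C/C=C/c3ccccc3)CC2)cc1`: 23300 nM
- Compound 3 `O=C(Nc1cccc(F)c1)C1CCN(C/C=C/c2ccccc2)CC1`: 51100 nM

The two steps reaching compound 3 are a 1.8-fold lower number from compound 1 to compound 3 (0.25 log units; within the scatter) and a 2.2-fold higher number from compound 2 to compound 3 (0.34 log units; beyond the scatter). The next change puts benzyl in place of 3-fluorophenyl on an amide-type nitrogen, giving compound 4 `O=C(NCc1ccccc1)C1CCN(C/C=C/c2ccccc2)CC1`: benzyl in place of 3-fluorophenyl on an amide-type nitrogen. Among the compounds with values here, no measured step introduces benzyl, so only the changes on the aromatic ring bear on it, and the largest of these is a 3.9-fold lower number from compound 1 to compound 2 (0.59 log units; beyond the scatter). With shifts this small, no step beyond the scatter is expected, and the expected step is a 1.2-fold higher number from compound 3 to compound 4 (0.07 log units; within the scatter). For compound 4 the estimate is 60000 nM, with an expected range of 22000 nM to 160000 nM.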

Compound 4, half-maximal inhibitory concentration: > 100000 nM
Compound 4 was reported as a limit; the forecaster's own chance of this, stated with the estimate: 10%; at least 1.6-fold (0.22 log units) between middle value and limit.
By their numbers in this assay, from the lowest: compound 2; then compounds 3 and 1 (each within the scatter of the next). At a limit, above all of these: compound 4.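

In this assay compound 4 gives a limit, not a number: the limit of > 100000 nM in this assay, at which 1 of the 4 values shown sits.

On the amide-type nitrogen, benzyl separates clearly only from 4-ethylphenyl, with an at least 4.2-fold higher number from compound 2 to compound 4 (0.63 log units; beyond the scatter). Against the other two groups the floors stay within the scatter, with an at least 1.9-fold higher number from compound 3 to compound 4 (0.29 log units; that floor lies within the scatter) and an at least 1.1-fold higher number from compound 1 to compound 4 (0.04 log units; that floor lies within the scatter), so benzyl is not shown to differ from 3-fluorophenyl or phenyl.

Going by these compounds, how far compound 4 lies past its limit stays open. Also open, on these data alone, is what a longer chain such as phenethyl, or an amine on the aromatic ring, would give at this position.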